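The source may report more compounds than this note shows. Statements on the series, on what has been measured and on what is new or still open speak of the compounds shown alone.

Compound 1 `CCCCSC(=S)C1=C(Nc2ccc(Cl)cc2)CC(C)(C)CC1=O`: in a functional assay on cells (blood, Homo sapiens) for inhibition, read by chemiluminescence, with a stated time of 30 min (on this read-out lower numbers stand for stronger inhibition and higher numbers for weaker inhibition), compound 1 reaches only the limit > 100 ug/mL.
Compound 2 `CC(=O)OC[C@H]1O[C@@H](SC(=S)C2=C(Nc3ccc(Cl)cc3)CC(C)(C)CC2=O)[C@H](OC(C)=O)[C@@H](OC(C)=O)[C@@H]1OC(C)=O`: in this assay compound 2 gives 90 ug/mL.
Compound 3 `CCCCSC(=S)C1=C(Nc2ccc(Br)cc2)CC(C)(C)CC1=O`: in this assay compound 3 reaches only the limit > 100 ug/mL.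

Compound 1 and compound 3 share a core and differ by one change, (bromo in place of chloro on an aromatic carbon). The step that the two limits leave unreadable from compound 1 to compound 3 cannot be sized because of the limit of > 100 ug/mL in this assay, at which 2 of the 3 values shown sit. Compound 2 carries another core; the difference between the two cores is not broken down here. Among the three, compound 2 alone gives a number rather than a limit. Compound 4 `CC(=O)OC[C@H]1O[C@@H](SC(=S)C2=C(Nc3ccc(Br)cc3)CC(C)(C)CC2=O)[C@H](OC(C)=O)[C@@H](OC(C)=O)[C@@H]1OC(C)=O` has not been measured; it differs from compound 2 by the same change, (bromo in place of chloro on an aromatic carbon). Because a step that the two limits leave unreadable from compound 1 to compound 3 is unreadable, the step from compound 2 to compound 4 is expected to be small, no change at the digits printed from compound 2 to compound 4 (within the scatter). Compound 4 is estimated at 90 ug/mL in this assay, expected between 40 ug/mL and 200 ug/mL.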

Compound 4, half-maximal inhibitory concentration: > 100 ug/mL
Compound 4: no number, only a limit (the forecaster's own chance of this, stated with the estimate: 45%); middle value at least 1.1-fold (0.04 log units) from the limit.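

In this assay, bromo in place of chloro on the aromatic carbon gives an at least 1.1-fold higher number from compound 2 to compound 4 (0.04 log units; that floor lies within the scatter). Compound 4 reaches only a limit, > 100 ug/mL, so this step has a floor but no measured size, and it does not show whether the true difference lies within the scatter or beyond it. The matching step on the core of compound 1 cannot be read, so the change cannot be compared between the two cores: the limit of > 100 ug/mL in this assay, at which 3 of the 4 values shown sit.

On these data alone, it remains open whether an amine or a carboxylic acid in place of chloro on that aromatic carbon would give a number on either core. As far as these compounds go, it also remains open whether a longer chain on the core of compound 1 would do so.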